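The source may hold more compounds than are shown below. What is called first, only, known or untested is meant among the compounds shown, and "the series" means these compounds.

Measured in a functional assay for inhibition, with Sus scrofa as the target; a lower number here means a stronger inhibitor, a higher number a weaker inhibitor:
Compound 1 `CC1(C)Oc2ccc(C#N)cc2[C@@H](n2ccccc2=O)[C@]1(C)O`: > 100000 nM, a limit of the assay
Compound 2 `CC1(C)Oc2ccc(C#N)cc2[C@@H](OC2=CC(=O)CC2)[C@]1(C)O`: 20 nM

Among the measured compounds shown here, compound 2, at 20 nM, holds the only actual number in this assay so far. Compound 3 `Cn1nc(O[C@@H]2c3cc(C#N)ccc3OC(C)(C)[C@@]2(C)O)ccc1=O` keeps the oxygen on a saturated carbon of compound 2 but changes the group it carries: a group of 8 heavy atoms (5 carbon, 2 nitrogen, 1 oxygen; one six-membered aromatic ring with 2 hetero atoms) in place of a group of 6 heavy atoms (5 carbon, 1 oxygen; one five-membered non-aromatic ring of carbon only), on an oxygen on a saturated carbon.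

For the measured compounds named here, only one measured step bears on this change. In an at least 5000-fold lower number from compound 1 to compound 2 (3.69 log units; beyond the scatter), a six-membered aromatic ring with 1 hetero atom gives way to a five-membered non-aromatic ring of carbon only. Compound 3 brings back a six-membered aromatic ring, now with 2 hetero atoms, so some loss is expected, though far less than that step, since the oxygen of compound 2 remains. In this assay, an estimated 5.0-fold higher number from compound 2 to compound 3 (0.70 log units; beyond the scatter) is expected, towards a higher number. For compound 3 the expected value is 100 nM, with an estimated range of 10 nM to 3000 nM.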

Compound 3, half-maximal inhibitory concentration: 30 nM
Beside the measured number, compound 3's estimate is 3.3-fold (0.52 log units) above it, and the stated range covers the measured number.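

In this assay, the group on the oxygen on a saturated carbon changes from 3-oxocyclopent-1-en-1-yl to a six-membered aromatic ring with 2 hetero atoms, and the step is a 1.5-fold higher number from compound 2 to compound 3 (0.18 log units; within the scatter), so the assay does not separate these two groups. A six-membered aromatic ring at this place is therefore compatible with a low number when it sits on the oxygen, which compound 1, with its ring directly on the saturated ring carbon, could not show. Nothing shown gives a reason for this result.

From the compounds shown here alone, whether a plain ethyl chain, or a ring carrying an amine or a carboxylic acid, would hold up on this oxygen stays open. Also open, going by these compounds, is what the oxygen itself contributes, as compound 1 changes the ring and the link together.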